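Removing Bromine from a Trimethoxyphenyl Enaminone Series

The compounds below may be only part of what the source reports. "The series", "measured", "known", "first", "only" and "open" are said of these compounds alone.

Three compounds have been measured in a functional assay on A549 cells (Homo sapiens) for antiproliferative activity, read by sulforhodamine B assay, with a stated time of 48 h; a lower number here means a stronger inhibitor, a higher number a weaker inhibitor:

Compound 1, `COc1ccc2nc(-c3ccc(N/C=C\C(=O)c4cc(OC)c(OC)c(OC)c4)cc3)sc2c1`: 12100 nM
Compound 2, `COc1cc(C(=O)/C=C\Nc2ccc(-c3nc4cc(OC)c(OC)c(OC)c4s3)cc2C)c(Br)c(OC)c1OC`: 10300 nM
Compound 3, `COc1ccc2nc(-c3ccc(N/C=C\C(=O)c4cc(OC)c(OC)c(OC)c4Br)cc3)sc2c1`: 6000 nM

All three numbers lie close together, and none of the gaps between them exceeds the usual scatter. Compound 3 and compound 1 differ by hydrogen in place of bromo on an aromatic carbon; that step, a 2.0-fold higher number from compound 3 to compound 1 (0.30 log units; within the scatter), is small. Compound 4, `COc1cc(C(=O)/C=C\Nc2ccc(-c3nc4cc(OC)c(OC)c(OC)c4s3)cc2C)cc(OC)c1OC`, has not yet been measured. It differs from compound 2 by hydrogen in place of bromo on an aromatic carbon, the same change in the same surroundings. How the core of compound 2 differs from the core of compound 3 is not broken down here. The earlier step was small, so the new step is expected to be of like size, a 1.7-fold higher number from compound 2 to compound 4 (0.22 log units; within the scatter). Compound 4 is therefore estimated at 17000 nM, most likely between 8000 nM and 40000 nM.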

Compound 4, half-maximal inhibitory concentration: 23300 nM
Compound 4: the middle estimate sits 1.4-fold (0.14 log units) below what was measured; low and high end bracket the measured number.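

Replacing bromo with hydrogen gives a 2.3-fold higher number from compound 2 to compound 4 (0.35 log units; beyond the scatter) in this assay, a modest step toward a weaker inhibitor on this second core. Set beside the same change on the first core, the two steps match in size: the same change on two cores in this assay, a 2.0-fold higher number (0.30 log units; within the scatter) from compound 3 to compound 1 and a 2.3-fold higher number (0.35 log units; beyond the scatter) from compound 2 to compound 4, 1.1-fold (0.05 log units) apart, within the scatter of two such steps. So, in these two pairs, the change carries from one core to the other with a similar result, but two pairs cannot show that this would hold on a further core, and the numbers do not explain why.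

From the compounds shown here alone, whether another group at this position, such as chloro, fluoro or methyl, would match bromo or hydrogen remains open. Also open, going by these compounds, is how each difference between the two cores bears on activity by itself.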